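A halogen exchange on the aryl ring of compound 3

The source may hold more compounds than are shown below. What is called first, only, known or untested is meant among the compounds shown, and "the series" means these compounds.

Compound 3 `CC1=C(/C=C/C(=O)/C=C/c2ccccc2Br)C(C)(C)CCC1` gives 11400 nM in a functional assay on PC-3 cells (Homo sapiens) for cytotoxicity, read by sulforhodamine B assay, with a stated time of 48 h; on this read-out lower numbers stand for stronger inhibition and higher numbers for weaker inhibition. Among the three measured compounds it sits second highest, with compound 2 `CC1=C(/C=C/C(=O)/C=C/c2ccccc2Cl)C(C)(C)CCC1` at 11300 nM and compound 1 `CC1=C(/C=C/C(=O)/C=C/c2ccc(Br)cc2)C(C)(C)CCC1` at 18900 nM; the steps of a 1.7-fold lower number from compound 1 to compound 2 (0.22 log units; within the scatter), a 1.7-fold lower number from compound 1 to compound 3 (0.22 log units; within the scatter) and a 1.0-fold higher number from compound 2 to compound 3 (0.00 log units; within the scatter) all lie within the scatter. Compound 4 `CC1=C(/C=C/C(=O)/C=C/c2ccccc2F)C(C)(C)CCC1` differs from compound 3 by fluoro in place of bromo on an aromatic carbon. For the measured compounds named here, the one measured step that bears directly on a halogen exchange at this ring, a 1.0-fold higher number from compound 2 to compound 3 (0.00 log units; within the scatter), moved nothing beyond the scatter. The step expected from this exchange, a 1.1-fold higher number from compound 3 to compound 4 (0.02 log units; within the scatter), is therefore none beyond the scatter. Compound 4 is expected to give about 12000 nM, with a range from 6000 nM to 25000 nM.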

Compound 4, half-maximal inhibitory concentration: 3400 nM
For compound 4 the middle estimate is 3.5-fold (0.55 log units) above the measured one, outside the stated range (below it).
By their numbers in this assay, from the lowest: compound 4; then compounds 2, 3 and 1 (each within the scatter of the next).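

At this place, ortho to a large group, the identity of the halogen now matters: fluoro in place of bromo gives a 3.4-fold lower number from compound 3 to compound 4 (0.53 log units; beyond the scatter), and fluoro in place of chloro gives a 3.3-fold lower number from compound 2 to compound 4 (0.52 log units; beyond the scatter), whereas bromo and chloro had stayed within the scatter of each other. The 2-fluorophenyl group also separates from the 4-bromophenyl group, with a 5.6-fold lower number from compound 1 to compound 4 (0.74 log units; beyond the scatter). No measurement available here bears on why fluoro departs from the other two halogens.

The compounds shown leave open whether a methoxy group or an amine in this place would give a number nearer that of compound 4 or that of compound 3.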